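The source may report more compounds than this note shows. Statements on the series, on what has been measured and on what is new or still open speak of the compounds shown alone.

Measured so far in a functional assay on Flp-In T-REx293 cells for antagonist activity at Free fatty acid receptor 1 (Homo sapiens), read by calcium flux; a lower number here means a smaller maximal response, a higher number a larger maximal response:
compound 1, `Cc1ccccc1Oc1cc(F)cc(N2Cc3ccccc3S2(=O)=O)c1`, gives 71%
compound 2, `Cc1ccc(Oc2cc(F)cc(N3Cc4ccccc4S3(=O)=O)c2)cc1`, gives 52%

Compound 2 stands at the lowest of the two numbers in this assay; its nearest neighbour is compound 1, and the step of a number 19 percentage points lower from compound 1 to compound 2 (beyond the scatter) lies beyond the scatter, so the two are separated by a modest but real gap. That step turns on where the methyl sits on the phenoxy group and on nothing else.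

Compound 3, `N#Cc1ccc(Oc2cc(F)cc(N3Cc4ccccc4S3(=O)=O)c2)cc1`, is yet to be measured in this assay. Relative to compound 2 the change is cyano in place of methyl on an aromatic carbon.

Going by the values given here, no measured step touches this exchange: the only step in hand, a number 19 percentage points lower from compound 1 to compound 2 (beyond the scatter), moves a methyl from one position to another and keeps the group itself, whereas here the group is swapped outright. There is therefore no basis in the series for a direction, and the expectation defaults to no change beyond the scatter, with a wide margin either way. The step of a number 3 percentage points higher from compound 2 to compound 3 (within the scatter) is the expected outcome. Compound 3 is estimated at 55%, with a range from 35% to 75%.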

Compound 3, largest response reached (reported as Imax), in percent of the reference or control that the assay uses: 43%
For compound 3 the middle estimate is 12 percentage points above the measured one; the measured number falls inside the stated range.
By their numbers in this assay, from the lowest: compounds 3 and 2 (each within the scatter of the next); then compound 1.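

In this assay, cyano in place of methyl on an aromatic carbon, para to a large group, gives a step of a number 9 percentage points lower from compound 2 to compound 3 (within the scatter), so this position shows no separable difference between the two groups, even though cyano brings one more heavy atom and one hydrogen-bond acceptor. The second step, a number 28 percentage points lower from compound 1 to compound 3 (beyond the scatter), places compound 3 apart from compound 1 just as compound 2 is, so among these three compounds both 4-substituted phenoxy compounds are separated from the 2-methylphenyl compound and none goes against this, although this step changes the group and its place together and cannot be assigned to either alone. No measurement available here bears on the reason for these numbers.

Still open, as far as these compounds go, is whether the similarity of methyl and cyano extends to other groups on this aromatic carbon, such as an amine or a carboxylic acid, which could either stay with compounds 2 and 3 or part from them. Also open, from the compounds shown here alone, is how much of the gap to compound 1 would remain with a cyano group in place of the methyl of compound 1, or with a methoxy group at either place.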